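3-Methoxypropyl on the aromatic oxygen of compound 2

The source may hold more compounds than are shown below. What is called first, only, known or untested is meant among the compounds shown, and "the series" means these compounds.

In a functional assay on RAW264.7 cells (Mus musculus) for inhibition, read by Griess assay, with stated times of 1 h and 24 h (a higher number here means a weaker inhibitor, a lower number a stronger inhibitor), compound 1 (`O=C1OC(Cc2nc(-c3ccc(-c4ccccc4)cc3)no2)c2ccccc21`) gives > 10000 nM, which is a limit. Compound 2 (`COc1cc(OC)c2c(c1)C(C(O)c1ccc(O)cc1)OC2=O`) gives > 10000 nM, also a limit, so its position is known only as a bound. Compound 3 (`CCCCCCOc1ccc(C(O)C2OC(=O)c3c(OC)cc(OC)cc32)cc1`) gives 5360 nM, a true number. Within the data shown here, the one measured step at this oxygen is an at least 1.8-fold lower number from compound 2 to compound 3 (0.27 log units; that floor lies within the scatter). Compound 4 (`COCCCOc1ccc(C(O)C2OC(=O)c3c(OC)cc(OC)cc32)cc1`) carries 3-methoxypropyl in place of hydrogen on an oxygen on an aromatic ring, an open chain like the hexyl of compound 3. Among the measured compounds shown here, with only that step as a guide, a small lowering of the number is expected in this assay, possibly no more than the scatter. The estimated step is an at least 1.2-fold lower number from compound 2 to compound 4 (0.09 log units; that floor lies within the scatter). Compound 4 is expected at 8000 nM, with an estimated range from 3500 nM to 18000 nM.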

Compound 4, half-maximal inhibitory concentration: 1260 nM
Compound 4: the middle estimate sits 6.3-fold (0.80 log units) above what was measured, outside the stated range (below it).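

In this assay, among these compounds, 3-methoxypropyl on this aromatic oxygen gives an at least 7.9-fold lower number from compound 2 to compound 4 (0.89 log units; beyond the scatter), the first step at this position that clears the scatter. The nature of the chain also counts, as methoxy in place of propyl gives a 4.3-fold lower number from compound 3 to compound 4 (0.63 log units; beyond the scatter). The step from compound 2 is only a floor, not a size: the limit of > 10000 nM in this assay, at which 2 of the 4 values shown sit.

As far as these compounds go, whether this shift belongs to the chain oxygen alone or also to where it sits along the chain stays open. A 2-methoxyethyl chain, a longer ether chain or a chain ending in an amine would test this.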